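Pentyl in place of piperidinyl on the core of compound 3

A few compounds are considered here, and "the series" means these few. Any claim that something is new, unique, unknown or untested is made for them only; others in the source may bear on it.

Measured in an assay on cells for antagonist activity at transient receptor potential cation channel subfamily V member 1 (Homo sapiens), read by FLIPR and calcium flux, with a stated time of 6 min; on this read-out lower numbers stand for stronger inhibition and higher numbers for weaker inhibition:
compound 1 `CCCN(CCC)c1nc(C(C)(C)C)ccc1CNC(=O)C(C)c1ccc(NS(C)(=O)=O)c(F)c1` gives 2.5 nM
compound 2 `CC(C)COc1nc(C(C)(C)C)ccc1CNC(=O)C(C)c1ccc(NS(C)(=O)=O)c(F)c1` gives 0.6 nM
compound 3 `CC(C(=O)NCc1ccc(C(C)(C)C)cc1N1CCCCC1)c1ccc(NS(C)(=O)=O)c(F)c1` gives 1.9 nM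

Compound 3 stands second highest of the three numbers. Compound 1 is within the scatter of it, so no order between the two can be claimed; compound 2 gives a lower number than compound 3.

Compound 4 `CCCCCc1cc(C(C)(C)C)ccc1CNC(=O)C(C)c1ccc(NS(C)(=O)=O)c(F)c1` differs from compound 3 by pentyl in place of piperidin-1-yl on an aromatic carbon. For the measured compounds named here, the only measured step, a 4.2-fold lower number from compound 1 to compound 2 (0.62 log units; beyond the scatter), sits on a different core and exchanges a nitrogen-linked group for an oxygen-linked one, not for a carbon chain; it shows that this part of the series tolerates exchange of the group without loss, but it does not speak to removal of a ring and an acceptor in favour of an open chain. Going by the values given here, no measured pair covers that change directly.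

The expectation is therefore a step of no more than the scatter, if anything a slightly higher number: a 1.6-fold higher number from compound 3 to compound 4 (0.20 log units; within the scatter). Compound 4 is estimated at 3 nM, with a range from 1 nM to 10 nM.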

Compound 4, inhibition constant: 2.8 nM
Estimate against measurement, compound 4: 1.1-fold (0.03 log units) above; low and high end bracket the measured number.
By their numbers in this assay, from the lowest: compound 2; then compounds 3, 1 and 4 (each within the scatter of the next).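

In this assay, pentyl in place of piperidin-1-yl on this aromatic carbon gives a 1.5-fold higher number from compound 3 to compound 4 (0.17 log units; within the scatter) and so no difference that can be claimed between the two compounds. Unlike the earlier exchange of one hetero-atom-linked group for another, this change removes the ring, its nitrogen and its hydrogen-bond acceptor, and compound 4 still gives 2.8 nM, so none of the three is required at this position for a number in this range. Nothing measured here explains why the two groups are matched on this read-out.

On these data alone, it remains open whether this tolerance extends to a butyl or heptyl chain at the same carbon, or to a pentyl chain ending in an amine or a carboxylic acid. Also open, as far as these compounds go, is whether isobutoxy would carry over to the core of compound 3.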